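This account rests on a few compounds, and the source may have more. Where it says the series, first, only, none or still open, it means among the compounds named here.

Series values in a functional assay on HeLa cells (Homo sapiens) for antiproliferative activity, read by MTT assay, with a stated time of 48 h; on this read-out lower numbers stand for stronger inhibition and higher numbers for weaker inhibition:

Compound 1 `COc1ccc(C(=O)c2ccc(OC)c3c2OC(C)(C)C=C3)c(NC(=O)CBr)c1`: 2140 nM
Compound 2 `COc1ccc(C(=O)c2ccc(OC)c3c2C=CC(C)(C)O3)c(NC(=O)CBr)c1`: 3680 nM
Compound 3 `COc1ccc(C(=O)c2ccc3c(c2)C=CC(C)(C)O3)c(NC(=O)CBr)c1`: 3050 nM

The three compounds differ in the shared core and all carry the bromo group. Compound 3, at 3050 nM, lies within the usual scatter of both compound 2 and compound 1, so the numbers set no order among the three. Within the data shown here, no pair of measured compounds differs in one place only, and no measured compound lacks the bromo group. The size of the next step therefore cannot be read from any measured step and remains a judgement.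

The next compound is compound 4 `COc1ccc(C(=O)c2ccc3c(c2)C=CC(C)(C)O3)c(NC(=O)CO)c1`, which keeps the core of compound 3 and changes only the end of the side chain: hydroxy in place of bromo on a saturated chain carbon bound to a carbonyl carbon. This places hydroxy in place of bromo on a saturated chain carbon bound to a carbonyl carbon.

In this assay, a moderate shift towards weaker inhibition is expected, beyond the scatter but with wide uncertainty, and a step of no measurable size cannot be ruled out. The expected step is a 3.0-fold higher number from compound 3 to compound 4 (0.47 log units; beyond the scatter). For compound 4 the estimated value is 9000 nM, with an expected range of 2500 nM to 35000 nM.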

Compound 4, half-maximal inhibitory concentration: 240 nM
Estimate against measurement, compound 4: 38-fold (1.57 log units) above, outside the stated range (below it).
By their numbers in this assay, from the lowest: compound 4; then compounds 1, 3 and 2 (each within the scatter of the next).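

In this assay, among these compounds, hydroxy in place of bromo on a saturated chain carbon bound to a carbonyl carbon gives a 13-fold lower number from compound 3 to compound 4 (1.10 log units; beyond the scatter), the first step that can be read at all, and it runs towards stronger inhibition. The earlier compounds shown here all carry the bromo group, so they could not show that this position governs the read-out so strongly or that, on the core of compound 3, bromo is not required for inhibition at this level; compound 4 shows both. No measurement on hand explains why this change has this effect.

From the compounds shown here alone, it remains open whether the gain depends on hydroxy specifically or follows from the removal of bromo, a question that a methoxy group, an amine, a fluorine atom or a plain hydrogen at the same place would address, as would a longer chain carrying the hydroxy group. Going by these compounds, it is also open whether the same change gives a step of similar size on the cores of compound 1 and compound 2.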